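A few compounds are considered here, and "the series" means these few. Any claim that something is new, unique, unknown or untested is made for them only; others in the source may bear on it.

Compound 3 `CCCCCCCCc1ccc(OCC(=O)Cn2nnc(-c3cccc(C(=O)OC)c3)n2)cc1` gives 34 nM in an assay on microsomes from brain for inhibition of Fatty-acid amide hydrolase 1 (Rattus norvegicus), read by fluorescence and HPLC, with a stated time of 60 min (on this read-out lower numbers stand for stronger inhibition and higher numbers for weaker inhibition), the highest of the three numbers recorded, though the other two lie within the scatter of it: compound 1 `CCCCCCCCc1ccc(OCC(=O)Cn2nnc(SC)n2)cc1` gives 31 nM and compound 2 `CCCCCCCCc1ccc(OCC(=O)Cn2nnc(-c3ccccc3)n2)cc1` gives 24 nM. Compound 4 `CCCCCCCCc1ccc(OCC(=O)Cn2nnc(-c3cccnc3)n2)cc1` differs from compound 3 by pyridin-3-yl in place of 3-(methoxycarbonyl)phenyl on an aromatic carbon. The measured steps that bear on this change all stay within the scatter: a 1.4-fold higher number from compound 2 to compound 3 (0.15 log units; within the scatter), a 1.3-fold lower number from compound 1 to compound 2 (0.11 log units; within the scatter) and a 1.1-fold higher number from compound 1 to compound 3 (0.04 log units; within the scatter). Three different groups on that carbon thus gave numbers that cannot be told apart in this assay, so no step beyond the scatter is expected for compound 4. Compound 4 is therefore estimated at 28 nM, within 12 nM to 70 nM, a step of a 1.2-fold lower number from compound 3 to compound 4 (0.08 log units; within the scatter) that is expected to remain within the scatter.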

Compound 4, half-maximal inhibitory concentration: 23 nM
Compound 4: the middle estimate sits 1.2-fold (0.09 log units) above what was measured; the range from low to high includes it.
By their numbers in this assay, from the lowest: compounds 4, 2, 1 and 3 (each within the scatter of the next).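

The fourth group on this carbon, pyridin-3-yl, brings the first ring hetero atom to this position, yet a 1.0-fold lower number from compound 2 to compound 4 (0.02 log units; within the scatter) stays within the scatter in this assay. The other two steps, a 1.5-fold lower number from compound 3 to compound 4 (0.17 log units; within the scatter) and a 1.3-fold lower number from compound 1 to compound 4 (0.13 log units; within the scatter), also stay within it, so neither this ring nitrogen nor the loss of the larger 3-(methoxycarbonyl)phenyl separates these compounds. Nothing measured here accounts for this flat result. Going by these compounds, whether an amine or a carboxylic acid on this carbon would give a step beyond the scatter remains open.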